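A Sulfonamide Swap Tested for Cytotoxicity

The compounds below may be only part of what the source reports. "The series", "measured", "known", "first", "only" and "open" are said of these compounds alone.

Compound 1 `Cc1nc(Cl)sc1S(=O)(=O)N1CCC(N2CCC(C)CC2)CC1` belongs to a small set of sulfonamides examined in an ADME assay on HCT-116 cells (Homo sapiens) for cytotoxicity, read by CellTiter-Glo, with a stated time of 72 h; a lower number here means a stronger inhibitor, a higher number a weaker inhibitor. In this assay compound 1 gives > 10000 nM, which is a limit of the measurement rather than a number. Compound 2 `CC(=O)Nc1ccc(S(=O)(=O)N2CCC(N3CCC(C)CC3)CC2)c2ccccc12` carries a different aromatic group on the sulfonyl sulfur. In this assay compound 2 also gives > 10000 nM, again a limit. Compound 3 `Cc1cc(C)c(S(=O)(=O)N2CCC(c3ccccc3)CC2)c(C)c1` is a third member of the set. In this assay compound 3 gives > 5000 nM, once more a limit. Compound 1 thus stands at the same limit as compound 2 (the limit of > 10000 nM in this assay, at which 2 of the 3 values shown sit), while compound 3 sits at a different limit (the limit of > 5000 nM in this assay, at which 1 of the 3 values shown sits); no value in this set is a measured number.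

Compound 4 `CC1CCN(C2CCN(S(=O)(=O)c3ccccc3Br)CC2)CC1` is the not yet measured compound. Its structure differs from compound 1 at the sulfonyl sulfur (2-bromophenyl in place of 2-chloro-4-methyl-1,3-thiazol-5-yl on a sulfonyl sulfur). Within the data shown here, no step between measured compounds is available, so no pattern can be drawn from the set. Since every shown value is a limit, compound 4 is expected to remain weak, with the step that the limit leaves unreadable from compound 1 to compound 4 not exceeding the usual scatter. Compound 4 is estimated to give 15000 nM in this assay, within a range from 5000 nM to 50000 nM.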

Compound 4, half-maximal inhibitory concentration: > 5000 nM
Compound 4 ended at the assay's limit; the forecaster's own chance of this, stated with the estimate: 85%; the middle value does not contradict the limit.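

In this assay compound 4 gives > 5000 nM, which is a limit and not a number. Compound 1 also stands at a limit, and the step between compound 1 and compound 4 cannot be read. The compounds shown leave open whether 2-bromophenyl in place of 2-chloro-4-methyl-1,3-thiazol-5-yl on a sulfonyl sulfur changes cytotoxicity at all.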